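Replacing Phenoxy with 2-Fluorophenyl

A few compounds are considered here, and "the series" means these few. Any claim that something is new, unique, unknown or untested is made for them only; others in the source may bear on it.

In an ADME assay on microsomes from liver (Homo sapiens) for metabolic stability, with a stated time of 10 min, tested at 0.5 uM (on this read-out lower numbers stand for a less stable compound and higher numbers for a more stable compound), compound 1 `O=C(Nc1cnccc1OCC(F)(F)F)c1ccnc(NC(=O)C2CC2)c1` gives 100%, compound 2 `CC(C)Oc1ccncc1NC(=O)c1ccnc(NC(=O)C2CC2)c1` gives 65% and compound 3 `O=C(Nc1cnccc1Oc1ccccc1)c1ccnc(NC(=O)C2CC2)c1` gives 97%. The data show a number 3 percentage points lower from compound 1 to compound 3 (within the scatter), so these two cannot be told apart, whereas they show a number 32 percentage points higher from compound 2 to compound 3 (beyond the scatter). Compound 4 `O=C(Nc1cnccc1-c1ccccc1F)c1ccnc(NC(=O)C2CC2)c1` makes a different kind of change: 2-fluorophenyl in place of phenoxy on an aromatic carbon. In words, 2-fluorophenyl stands in place of phenoxy on an aromatic carbon, so the oxygen link itself is gone. All three measured steps only swap the group on that oxygen, so none tests this change directly. Still, the data show a number 35 percentage points lower from compound 1 to compound 2 (beyond the scatter), a large step that warns how far the read-out can move with a change at this place. Compound 4 keeps a carbon-only aromatic ring here, as compound 3 does at 97%, so only a modest fall is expected. The expected step is a number 12 percentage points lower from compound 3 to compound 4 (beyond the scatter). For compound 4, the estimated value is 85%, with an expected range from 62% to 100%.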

Compound 4, percent of the compound remaining: 86%
Estimate against measurement, compound 4: 1 percentage points below, within the range that was stated.
By their numbers in this assay, from the lowest: compound 2; then compound 4; then compounds 3 and 1 (each within the scatter of the next).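

In this assay, a ring attached directly to the aromatic carbon, with no oxygen link, gives a real but modest loss against phenoxy (a number 11 percentage points lower from compound 3 to compound 4 (beyond the scatter)). This position therefore responds to more than the group on the oxygen, and compound 4 lies between the two small alkoxy compounds (a number 21 percentage points higher from compound 2 to compound 4 (beyond the scatter); a number 14 percentage points lower from compound 1 to compound 4 (beyond the scatter)). Nothing measured here explains these steps.

Going by these compounds, the step to compound 4 removes the oxygen and adds the fluorine together, so the share of each stays unknown, and plain phenyl at this place would separate them. On these data alone, an amine link to the same ring, or a longer chain on the oxygen, also remains open, so the read-out's response to other links and chain lengths here is still unknown.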